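This account rests on a few compounds, and the source may have more. Where it says the series, first, only, none or still open, it means among the compounds named here.

In a functional assay on B16-F10 cells (Mus musculus) for antiproliferative activity, read by MTT assay, with a stated time of 48 h (a higher number here means a weaker inhibitor, a lower number a stronger inhibitor), three compounds with a shared core have been measured so far. Compound 1 (`CC(=O)N1N=C(c2ccc3ccccc3c2)OC1c1ccccc1Br`) gives 6.98 ug/mL in this test, compound 2 (`CC(=O)N1N=C(c2ccc3ccccc3c2)OC1c1ccc(Br)cc1`) gives 4.68 ug/mL and compound 3 (`CC(=O)N1N=C(c2ccc3ccccc3c2)OC1c1ccc([N+](=O)[O-])cc1`) gives 9.32 ug/mL in the same test. Compound 3 stands level with the other two, as its gaps to both lie within the usual scatter of repeat measurements.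

The next compound is compound 4 (`CC(=O)N1N=C(c2ccc3ccccc3c2)OC1c1ccncc1`), with pyridin-4-yl in place of 4-nitrophenyl on a saturated ring carbon. Among the compounds with values here, none of the measured compounds has a hetero atom in the aromatic ring at this carbon, so no measured step shows this exact change. The closest evidence comes from other swaps in the same group: 4-bromophenyl in place of 2-bromophenyl gave a 1.5-fold lower number from compound 1 to compound 2 (0.17 log units; within the scatter) and 4-nitrophenyl in place of 2-bromophenyl gave a 1.3-fold higher number from compound 1 to compound 3 (0.13 log units; within the scatter) while nitro in place of bromo gave a 2.0-fold higher number from compound 2 to compound 3 (0.30 log units; within the scatter) so no step beyond the scatter is expected in this assay for the new swap. Three compounds are a thin basis, however, so the range is kept wide. The estimated step is a 1.3-fold lower number from compound 3 to compound 4 (0.12 log units; within the scatter) in this test. Compound 4 is expected to give about 7 ug/mL in this test, with an estimated range from 3 ug/mL to 16 ug/mL in the same test.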

Compound 4, half-maximal inhibitory concentration: 2.97 ug/mL
Compound 4: middle estimate off by 2.4-fold (0.37 log units), on the high side; the measured number lies below the stated range.
By their numbers in this assay, from the lowest: compounds 4, 2, 1 and 3 (each within the scatter of the next, the first and the last beyond it).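

In this assay this position now shows its first steps beyond the scatter: pyridin-4-yl, a ring with one hetero atom, gives a 3.1-fold lower number from compound 3 to compound 4 (0.50 log units; beyond the scatter) and a 2.4-fold lower number from compound 1 to compound 4 (0.37 log units; beyond the scatter), both modest, whereas every earlier swap among the all-carbon rings stayed within the scatter. Against 4-bromophenyl the same ring gives a 1.6-fold lower number from compound 2 to compound 4 (0.20 log units; within the scatter), so the outcome depends on which group is replaced, and compound 2 and compound 4 cannot be told apart in this test, while a hetero atom in this aromatic ring is clearly tolerated. Nothing measured for these compounds speaks to what lies behind these steps.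

From the compounds shown here alone, a single pyridine placement cannot show whether the location of the hetero atom in the ring matters, so it remains open how pyridin-3-yl, pyridin-2-yl or a pyrimidine ring with two ring nitrogens would compare at this carbon. Going by these compounds, it is also open whether the aromatic ring is needed at all, which a saturated piperidine ring carrying an amine, or a simple alkyl chain, would begin to test.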